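Replacing the Methylsulfamoyl Group on a Serotonin Receptor Ligand

The source may hold more compounds than are shown below. What is called first, only, known or untested is meant among the compounds shown, and "the series" means these compounds.

Measured so far:
compound 1, `NC[C@@H]1CCCc2cc(S(=O)(=O)c3c[nH]c4ccccc34)ccc21`: 0.0501 nM
compound 2, `CNS(=O)(=O)NC[C@@H]1CCCc2cc(S(=O)(=O)c3cccc(F)c3)ccc21`: 1 nM

In an assay on isolated protein for displacement of a labelled ligand from 5-hydroxytryptamine receptor 6 (Homo sapiens) (a higher number here means a weaker inhibitor, a lower number a stronger inhibitor), compound 2 gives 1 nM, the higher of the two numbers; compound 1 gives 0.0501 nM, a gap that lies beyond the usual scatter. Compound 3, `O=C1CN=C(NC[C@@H]2CCCc3cc(S(=O)(=O)c4cccc(F)c4)ccc32)N1`, has not yet been measured. It differs from compound 2 in one place: a group of 6 heavy atoms (3 carbon, 2 nitrogen, 1 oxygen; one five-membered non-aromatic ring with 2 hetero atoms) in place of a group of 5 heavy atoms (1 carbon, 1 nitrogen, 2 oxygen, 1 sulfur; no ring), on an amine nitrogen. Among the measured compounds shown here, no measured pair shows a change of this kind, so the direction is uncertain. The step of a 2.0-fold higher number from compound 2 to compound 3 (0.30 log units; within the scatter) is expected to be small, within the scatter. For compound 3 the expected value in this assay is 2 nM, with a range from 0.3 nM to 15 nM.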

Compound 3, inhibition constant: 0.1 nM
Estimate against measurement, compound 3: 20-fold (1.30 log units) above; the whole stated range lies above it.
By their numbers in this assay, from the lowest: compounds 1 and 3 (each within the scatter of the next); then compound 2.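

In this assay, putting the five-membered ring in place of the methylsulfamoyl group on the amine nitrogen gives a 10-fold lower number from compound 2 to compound 3 (1.00 log units; beyond the scatter) and so shows that this position accepts a ring as well as an open chain. The counts of hydrogen-bond donors and acceptors and the net charge are the same for both groups, so these counts do not separate the two compounds. No measurement shown here accounts for the difference.

Going by these compounds, whether an acetyl group or a urea on the same nitrogen would match compound 3 stays open.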